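This account rests on a few compounds, and the source may have more. Where it says the series, first, only, none or still open, it means among the compounds named here.

Measured compounds:
Compound 1, `COc1cc(F)c(NC(=O)c2ccncc2)cc1Nc1nccc(-c2cn(C)c3ccccc23)n1`: in a functional assay on NCI-H1975 cells (Homo sapiens) for antiproliferative activity, read by MTT assay, with a stated time of 72 h (on this read-out higher numbers stand for weaker inhibition and lower numbers for stronger inhibition), compound 1 gives 4370 nM.
Compound 2, `COc1cc(F)c(NC(=O)c2ccncc2OC)cc1Nc1nccc(-c2cn(C)c3ccccc23)n1`: compound 2 gives 4120 nM.
Compound 3, `COc1cc(N(C)C)c(NC(=O)c2ccncc2)cc1Nc1nccc(-c2cn(C)c3ccccc23)n1`: compound 3 gives 1470 nM.

Among these three, compound 3 carries the lowest number, and the gap from it to each of the other two lies beyond the scatter; the one measured step leading to it, a 3.0-fold lower number from compound 1 to compound 3 (0.47 log units; beyond the scatter), is modest but real. Compound 4, `COc1cc(N(C)C)c(NC(=O)c2ccncc2OC)cc1Nc1nccc(-c2cn(C)c3ccccc23)n1`, differs from compound 3 in a single place: methoxy in place of hydrogen on an aromatic carbon. The same change has been tried once already on this series, and there it produced a 1.1-fold lower number from compound 1 to compound 2 (0.03 log units; within the scatter), which is within the scatter. Among the measured compounds shown here, no other measured step touches this position. On that basis the expected step is a 1.1-fold lower number from compound 3 to compound 4 (0.02 log units; within the scatter), with no change beyond the scatter in either direction. Compound 4 is therefore expected to give about 1400 nM, with a plausible range from 600 nM to 3200 nM.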

Compound 4, half-maximal inhibitory concentration: 12100 nM
For compound 4 the middle estimate is 8.6-fold (0.94 log units) below the measured one, and the stated range ends below it.
By their numbers in this assay, from the lowest: compound 3; then compounds 2 and 1 (each within the scatter of the next); then compound 4.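

In this assay, the change from pyridin-4-yl to 3-methoxypyridin-4-yl gives an 8.2-fold higher number from compound 3 to compound 4 (0.92 log units; beyond the scatter) on the core carrying dimethylamino, so the methoxy is not silent at this position on every core. Dimethylamino in place of fluoro also loses its earlier gain, giving a 2.9-fold higher number from compound 2 to compound 4 (0.47 log units; beyond the scatter) when the methoxy is present. The two changes therefore do not simply add, and the effect of each depends on the other: the same change on two cores in this assay, a 1.1-fold lower number (0.03 log units; within the scatter) from compound 1 to compound 2 and an 8.2-fold higher number (0.92 log units; beyond the scatter) from compound 3 to compound 4, 8.7-fold (0.94 log units) apart, beyond the scatter of two such steps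

The compounds leave open why this dependence arises, and whether a hydroxyl, an ethoxy or a chlorine at the same position would follow the methoxy on the dimethylamino core. They also leave open whether a cyclic amine such as pyrrolidine in place of dimethylamino would tolerate the methoxy.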